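Sulfamoyl to Methylsulfonyl on the Chain of Compound 2

This account rests on a few compounds, and the source may have more. Where it says the series, first, only, none or still open, it means among the compounds named here.

Measured so far:
Compound 1, `N#Cc1cccc(N/C(=N\O)c2nonc2SCCNC(=O)CS(N)(=O)=O)c1`, 240 nM
Compound 2, `NS(=O)(=O)CC(=O)NCCSc1nonc1/C(=N/O)Nc1ccc(F)c(C(F)F)c1`, 73 nM

Both numbers come from an assay for inhibition of Indoleamine 2,3-dioxygenase 1 (Homo sapiens), read by fluorescence, with a stated time of 1 h; on this read-out higher numbers stand for weaker inhibition and lower numbers for stronger inhibition. Compound 2 holds the lower of the two numbers, and the step of a 3.3-fold lower number from compound 1 to compound 2 (0.52 log units; beyond the scatter) lies beyond the scatter. Compound 3, `CS(=O)(=O)CC(=O)NCCSc1nonc1/C(=N/O)Nc1ccc(F)c(C(F)F)c1`, differs from compound 2 by methyl in place of amino on a sulfonyl sulfur. Within the data shown here, the only measured step concerns the aryl group on an amine nitrogen, not the sulfonyl sulfur, so no measured step bears on this change. For compound 3 the step of a 1.2-fold higher number from compound 2 to compound 3 (0.09 log units; within the scatter) is therefore expected to stay within the scatter. Compound 3 is estimated at 90 nM, within 35 nM to 250 nM.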

Compound 3, half-maximal inhibitory concentration: 100 nM
The estimate for compound 3 lay 1.1-fold (0.05 log units) below the measured number; the range from low to high includes it.
By their numbers in this assay, from the lowest: compounds 2 and 3 (each within the scatter of the next); then compound 1.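

Among these compounds, with methyl in place of amino on a sulfonyl sulfur, the result is a 1.4-fold higher number from compound 2 to compound 3 (0.14 log units; within the scatter) and so gives no sign that this position depends on the amino, which the earlier compounds left unchanged. The hydrogen-bond donor counted on that amino can therefore go without a change beyond the scatter. Nothing available accounts for this result.

Open, going by these compounds, is whether an ethyl or a dimethylamino on the sulfonyl sulfur, or a carboxylic acid in place of the whole sulfonyl, would stay within the scatter. Also open, on these data alone, is whether the same exchange holds with the 3-cyanophenyl of compound 1.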